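Replacing 4-fluorophenyl with 6-fluoropyridin-3-yl

This account rests on a few compounds, and the source may have more. Where it says the series, first, only, none or still open, it means among the compounds named here.

Measured so far in a functional assay on A549 cells (Homo sapiens) for antiproliferative activity, read by sulforhodamine B assay, with a stated time of 48 h; a higher number here means a weaker inhibitor, a lower number a stronger inhibitor:
Compound 1 `COc1ccc(C(=O)/C=C/c2ccccc2-c2ccc(F)nc2)cc1OC` gives 17000 nM
Compound 2 `COc1ccc(C(=O)/C=C/c2ccccc2-c2ccc(F)cc2)cc1O` gives 940 nM

Compound 2 has the lower of the two numbers, which makes it the stronger inhibitor of the pair, and the gap between the two lies beyond the usual scatter. These two compounds differ in more than one place, so neither value isolates the effect of a single change.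

Compound 3 `COc1ccc(C(=O)/C=C/c2ccccc2-c2ccc(F)nc2)cc1O` departs from compound 2 in one place: 6-fluoropyridin-3-yl in place of 4-fluorophenyl on an aromatic carbon, ortho to a large group (6-fluoropyridin-3-yl in place of 4-fluorophenyl on an aromatic carbon). Compound 1 carries the same 6-fluoropyridin-3-yl group and gives 17000 nM in this assay, so a loss of strength is expected rather than a gain. Compound 1 also differs from compound 2 in a second place, so this expectation remains uncertain. The expected change is a moderate weakening, a 2.7-fold higher number from compound 2 to compound 3 (0.42 log units; beyond the scatter) in this assay, and this rests on very few data. For compound 3 the estimated value is 2500 nM with an expected span from 700 nM to 9000 nM as the likely range.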

Compound 3, half-maximal inhibitory concentration: 3200 nM
Compound 3: the middle estimate sits 1.3-fold (0.11 log units) below what was measured, and the stated range covers the measured number.
By their numbers in this assay, from the lowest: compound 2; then compound 3; then compound 1.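

In this assay the swap of 4-fluorophenyl for 6-fluoropyridin-3-yl, on an aromatic carbon ortho to a large group, can now be read on its own: it gives a 3.4-fold higher number from compound 2 to compound 3 (0.53 log units; beyond the scatter) and so costs strength, though compound 3 remains clearly more active than compound 1. Compound 3 also isolates the second difference in the set, since hydrogen in place of methyl on an oxygen on an aromatic ring gives a 5.3-fold lower number from compound 1 to compound 3 (0.73 log units; beyond the scatter), a gain in strength that is somewhat larger than the loss from the ring swap. The wide gap between compound 1 and compound 2 therefore breaks into two separate single changes, and nothing measured here accounts for the direction or size of either one.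

Still open, as far as these compounds go, is whether the hydrogen-for-methyl step would have a similar size with 4-fluorophenyl in place of 6-fluoropyridin-3-yl. The compounds shown also give no reading for other groups at this place, such as unsubstituted phenyl or 6-aminopyridin-3-yl, so it remains unknown how the strength would respond to them.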